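N-Aryl sulfonamide variation in a nicotinamide phosphoribosyltransferase inhibitor series

A few compounds are considered here, and "the series" means these few. Any claim that something is new, unique, unknown or untested is made for them only; others in the source may bear on it.

Measured compounds:
compound 1 `Cc1ccc(NS(=O)(=O)c2cccc(CCCCCCNC(=O)/C=C/c3cccnc3)c2)cc1`: 9.78 nM
compound 2 `Cc1cccc(NS(=O)(=O)c2cccc(CCCCCCNC(=O)/C=C/c3cccnc3)c2)c1`: 12.3 nM
compound 3 `Cc1ccc(C)c(NS(=O)(=O)c2cccc(CCCCCCNC(=O)/C=C/c3cccnc3)c2)c1`: 11.6 nM

In an assay on isolated protein for inhibition of Nicotinamide phosphoribosyltransferase (Homo sapiens), read by WST assay, with stated times of 60 min, 5 min and 30 min, in the presence of a further agent that is not named here (a lower number here means a stronger inhibitor, a higher number a weaker inhibitor), compound 3 stands second highest of the three numbers, with compound 2 nearest and compound 1 furthest, all three values within the scatter of one another. Compound 4 `CCc1ccc(NS(=O)(=O)c2cccc(CCCCCCNC(=O)/C=C/c3cccnc3)c2)cc1` differs from compound 3 by 4-ethylphenyl in place of 2,5-dimethylphenyl on a sulfonamide nitrogen. The steps bearing on this aryl change are a 1.2-fold higher number from compound 1 to compound 3 (0.07 log units; within the scatter), a 1.3-fold higher number from compound 1 to compound 2 (0.10 log units; within the scatter) and a 1.1-fold lower number from compound 2 to compound 3 (0.03 log units; within the scatter); none moves the number beyond the scatter. Moving or swapping small alkyl groups on this phenyl has so far left this assay essentially unchanged, so no step beyond the scatter is expected here either, in either direction. The expected step is a 1.1-fold lower number from compound 3 to compound 4 (0.02 log units; within the scatter). Compound 4 is estimated at 11 nM, with a range from 5 nM to 25 nM.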

Compound 4, half-maximal inhibitory concentration: 31.5 nM
Beside the measured number, compound 4's estimate is 2.9-fold (0.46 log units) below it; the measured number lies above the stated range.
By their numbers in this assay, from the lowest: compounds 1, 3 and 2 (each within the scatter of the next); then compound 4.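

In this assay, for the compounds shown here, the group on the sulfonamide nitrogen is no longer indifferent: methyl in place of hydrogen on the saturated chain carbon gives a 3.2-fold higher number from compound 1 to compound 4 (0.51 log units; beyond the scatter) and is the first change here to pass the scatter. With a 2.7-fold higher number from compound 3 to compound 4 (0.43 log units; beyond the scatter) on identical atoms, how the carbons are arranged counts, not just how many there are, and a 2.6-fold higher number from compound 2 to compound 4 (0.41 log units; beyond the scatter) points the same way. Nothing shown accounts for this step.

Open, from the compounds shown here alone, is whether a propyl group or a longer chain in place of the ethyl raises the number further. A methoxy group there is also untested in these compounds.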